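The compounds below may be only part of what the source reports. "The series", "measured", "known", "first", "only" and "open" are said of these compounds alone.

Compound 1 `CCOc1ccc(-c2cccc(NC(=O)N(C)C)c2)cc1` — 68%
Compound 2 `CN(C)C(=O)Nc1cccc(-c2ccc(N(C)C)cc2)c1` — 98%

In an assay on COS-7 cells for inhibition of patatin-like phospholipase domain-containing protein 2 (Mus musculus), tested at 200 uM (a lower number here means less inhibition, a higher number more inhibition at the concentration tested (going by the name of the read-out)), compound 2 gives 98%, the highest of the two numbers; the nearest is compound 1, which gives 68%. Within the data shown here, the one measured step, a number 30 percentage points higher from compound 1 to compound 2 (beyond the scatter), comes from dimethylamino in place of ethoxy on an aromatic carbon, a change at the far end of the shared core.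

Compound 3 `CC(C)OC(=O)Nc1cccc(-c2ccc(N(C)C)cc2)c1` keeps that dimethylamino and instead alters the carbonyl end: isopropoxy in place of dimethylamino on a carbonyl carbon. Among the measured compounds shown here, no measured step touches this carbonyl carbon, so the step from compound 1 to compound 2 does not bear on it directly; it tells only that compound 2 already sits near the top of the read-out, leaving room chiefly downward. A modest decrease is therefore expected, a number 16 percentage points lower from compound 2 to compound 3 (beyond the scatter), with wide uncertainty. For compound 3 the estimated value in this assay is 82%, expected to fall between 50% and 100%.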

Compound 3, a percentage reported as inhibition, at one concentration (the size of the read-out at that concentration, not a potency): 69%
Compound 3: the middle estimate sits 13 percentage points above what was measured; measured number inside the range.
By their numbers in this assay, from the lowest: compounds 1 and 3 (each within the scatter of the next); then compound 2.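

In this assay, the carbonyl end of the series matters as well as the far end of the shared core: a number 29 percentage points lower from compound 2 to compound 3 (beyond the scatter), with isopropoxy in place of dimethylamino on a carbonyl carbon. With dimethylamino held constant on the aromatic carbon, this single pair places (dimethylcarbamoyl)amino above (isopropoxycarbonyl)amino, although one pair establishes no general pattern. Nothing available explains the step.

Still open, from the compounds shown here alone, is how other groups on this carbonyl carbon would read, such as methylamino, an unsubstituted amino group or a longer alkoxy chain like butoxy. The compounds shown also leave open whether the same isopropoxy change gives a comparable step when ethoxy replaces dimethylamino at the far end of the shared core.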